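The source may hold more compounds than are shown below. What is called first, only, known or untested is meant among the compounds shown, and "the series" means these compounds.

Measured compounds:
- compound 1, `N[C@H]1CC[C@H](Nc2c(C(=O)NCc3ccc(Cl)cc3)nc(Br)c3cccnc23)CC1`: 4000 nM
- compound 2, `N[C@H]1CC[C@H](Nc2c(C(=O)NCc3cccc(C(F)(F)F)c3)nc(Br)c3cccnc23)CC1`: "not determined" (no result reported)

Compound 1 was tested in a functional assay on HCT-116 cells (Homo sapiens) for cytotoxicity, read by MTT assay, with a stated time of 72 h (on this read-out lower numbers stand for stronger inhibition and higher numbers for weaker inhibition), and gave 4000 nM. Going by these compounds, compound 2 has no single number in this assay, so where it stands is unknown; it shares the core of compound 1 and differs only in the group on the benzyl ring. Compound 3, `N[C@H]1CC[C@H](Nc2c(C(=O)NCc3ccccc3)nc(Br)c3cccnc23)CC1`, is the next compound and is to be measured in this assay. Going from compound 2 to compound 3 the change is hydrogen in place of trifluoromethyl on an aromatic carbon. Among the compounds with values here, no step between two measured compounds is available, so there is no measured guide to how large an effect such a change has in this assay. Because only compound 1 with its value of 4000 nM offers a reference point, the expectation is that compound 3 lands in that same region, perhaps somewhat weaker. Compound 3 is estimated to give 6000 nM in this assay, with a range from 2000 nM to 20000 nM.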

Compound 3, half-maximal inhibitory concentration: 7000 nM
For compound 3 the middle estimate is 1.2-fold (0.07 log units) below the measured one; the measured number falls inside the stated range.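

In this assay, hydrogen in place of chloro on the aromatic ring of the benzyl group gives a 1.8-fold higher number from compound 1 to compound 3 (0.24 log units; within the scatter), a step within the usual scatter, so these two compounds cannot be told apart and the chloro group shows no measurable effect here. The step from compound 2 to compound 3 cannot be read, since compound 2 has no number. No measured information is available to explain the result.

Still open, going by these compounds, is whether an amine or a carboxylic acid on this ring would shift the number beyond the scatter. On these data alone, it is also open whether a longer chain in place of the benzyl group would do so, and one comparison on a single ring cannot settle how this position behaves in general.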